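This account rests on a few compounds, and the source may have more. Where it says the series, first, only, none or still open, it means among the compounds named here.

Compound 2 `CC(C)(C)NS(=O)(=O)c1cccc(NC(=O)c2ccc(NS(=O)(=O)C3(C)CC3)cc2N2CCC3(CC2)CC3)c1` gives the lower of the two numbers measured in a functional assay on OVCAR-3 cells (Homo sapiens) for activation, with a stated time of 24 h (a lower number here means that less compound is needed, a higher number that more compound is needed for the effect), namely 11 nM. Compound 1 `O=C(Nc1cccc(S(=O)(=O)C2COC2)c1)c1cccnc1N1CCC2(CC1)CC2`, built on a different core, gives 14800 nM in this assay, a gap well beyond the scatter. Compound 3 `CC(C)(C)NS(=O)(=O)c1cccc(NC(=O)c2ccc(NS(C)(=O)=O)cc2N2CCC3(CC2)CC3)c1` differs from compound 2 in one place: methyl in place of 1-methylcyclopropyl on a sulfonyl sulfur. Among the measured compounds shown here, no measured pair shows this exact change, so only a modest loss is expected, a 2.3-fold higher number from compound 2 to compound 3 (0.36 log units; beyond the scatter) in this assay. Compound 3 is therefore estimated at 25 nM in this assay, within a range from 8 nM to 80 nM.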

Compound 3, half-maximal effective concentration: 16 nM
The estimate for compound 3 lay 1.6-fold (0.19 log units) above the measured number; the range from low to high includes it.
By their numbers in this assay, from the lowest: compounds 2 and 3 (each within the scatter of the next); then compound 1.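

Replacing 1-methylcyclopropyl with methyl on a sulfonyl sulfur whose other neighbour is the sulfonamide nitrogen gives a 1.5-fold higher number from compound 2 to compound 3 (0.16 log units; within the scatter) in this assay. The three-membered carbon ring is therefore not required to keep the number in the range of compound 2 and compound 3, and this position accepts both a small and a larger carbon group. Nothing measured here gives a reason for this. From the compounds shown here alone, whether an amine or a carboxylic acid would be accepted in place of these carbon groups remains open, as does the effect of a longer chain.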